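Replacing the aryl group of compound 3 with a carboxy-bearing one

The compounds below may be only part of what the source reports. "The series", "measured", "known", "first", "only" and "open" are said of these compounds alone.

Measured in a functional assay on HCT-116 cells (Homo sapiens) for antiproliferative activity, read by MTT assay, with a stated time of 48 h; on this read-out lower numbers stand for stronger inhibition and higher numbers for weaker inhibition:
Compound 1 `COc1ccc(-c2cc3c(cn2)[nH]c(=O)n3-c2cc(OC)c(OC)c(OC)c2)cc1`: 840 nM
Compound 2 `COc1ccc(-c2cc3c(cn2)[nH]c(=O)n3-c2cc(OC)c(OC)c(OC)c2)cn1`: 830 nM
Compound 3 `CCOc1ccc(-c2cc3c(cn2)[nH]c(=O)n3-c2cc(OC)c(OC)c(OC)c2)cc1F`: 7220 nM

Compound 3 has the highest number of the three. In compound 4 `COc1ccc(-c2cc3c(cn2)[nH]c(=O)n3-c2cc(OC)c(OC)c(OC)c2)cc1C(=O)O`, 3-carboxy-4-methoxyphenyl replaces 4-ethoxy-3-fluorophenyl on an aromatic carbon (3-carboxy-4-methoxyphenyl in place of 4-ethoxy-3-fluorophenyl on an aromatic carbon). The relevant measured changes at this place are an 8.6-fold higher number from compound 1 to compound 3 (0.93 log units; beyond the scatter) and an 8.7-fold higher number from compound 2 to compound 3 (0.94 log units; beyond the scatter), both beyond the scatter, while a 1.0-fold lower number from compound 1 to compound 2 (0.01 log units; within the scatter) stays within it. Among the compounds with values here, compound 4 keeps the methoxy group of compound 1, at 840 nM, but no measured compound carries a carboxy group, so a position between compound 1 and compound 3 is expected. The expected change in this assay is small: a 1.8-fold lower number from compound 3 to compound 4 (0.26 log units; within the scatter). The estimate for compound 4 is 4000 nM, with an expected range of 1200 nM to 15000 nM.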

Compound 4, half-maximal inhibitory concentration: 3070 nM
Compound 4: the middle estimate sits 1.3-fold (0.11 log units) above what was measured; low and high end bracket the measured number.
By their numbers in this assay, from the lowest: compounds 2 and 1 (each within the scatter of the next); then compound 4; then compound 3.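

In this assay, carboxy in place of hydrogen on the aryl group gives a 3.7-fold higher number from compound 1 to compound 4 (0.56 log units; beyond the scatter), so a single added group at this place moves the number beyond the scatter. The same 3-carboxy-4-methoxyphenyl group gives a 2.4-fold lower number from compound 3 to compound 4 (0.37 log units; beyond the scatter) against 4-ethoxy-3-fluorophenyl and a 3.7-fold higher number from compound 2 to compound 4 (0.57 log units; beyond the scatter) against 6-methoxypyridin-3-yl, which places compound 4 between the two earlier levels. No measurement at hand explains these steps.

Going by these compounds, whether a methyl ester, a primary amide or an aminomethyl group would behave like the carboxy group remains open. So does the effect of a carboxy group on the 6-methoxypyridin-3-yl ring.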